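Cyclopropyl for ethyl on compound 2

The compounds below may be only part of what the source reports. "The series", "measured", "known", "first", "only" and "open" are said of these compounds alone.

In a functional assay on HeLa cells (Homo sapiens) for antiproliferative activity, read by MTT assay, with a stated time of 72 h (a higher number here means a weaker inhibitor, a lower number a stronger inhibitor), the measured compounds give these values:
Compound 1 `CCn1cc(C(=O)O)c(=O)c2cc(F)c(N3CCN(C(=N)NS(=O)(=O)c4ccc(C(F)(F)F)cc4)CC3)cc21` gives 32 nM
Compound 2 `CCn1cc(C(=O)O)c(=O)c2cc(F)c(N3CCN(C(=N)NS(=O)(=O)c4cccc(Cl)c4)CC3)cc21` gives 32 nM
Compound 3 `CCn1cc(C(=O)O)c(=O)c2cc(F)c(N3CCN(C(=N)NS(=O)(=O)c4ccccc4Cl)CC3)cc21` gives 32 nM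

Compound 2 at 32 nM stands level with compounds 1 and 3. Compound 4 `N=C(NS(=O)(=O)c1cccc(Cl)c1)N1CCN(c2cc3c(cc2F)c(=O)c(C(=O)O)cn3C2CC2)CC1` carries cyclopropyl in place of ethyl on an aromatic nitrogen. The measured steps bear on this only indirectly: no change at the digits printed from compound 1 to compound 2 (within the scatter) and no change at the digits printed from compound 1 to compound 3 (within the scatter) and also no change at the digits printed from compound 2 to compound 3 (within the scatter) are all changes on a sulfonyl sulfur. Among the measured compounds shown here, no measured step touches the ethyl group, so the data give no direction, and no step beyond the scatter is expected. The expected step is no change at the digits printed from compound 2 to compound 4 (within the scatter) in this assay on this reasoning. For compound 4 the estimated value is 32 nM with an expected range from 12 nM to 90 nM at its upper end.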

Compound 4, half-maximal inhibitory concentration: 32 nM
Compound 4: the middle estimate sits on the measured number at the digits printed; measured number inside the range.
By their numbers in this assay, from the lowest: compounds 1, 2, 3 and 4 (each within the scatter of the next).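

Unlike the earlier steps, all on a sulfonyl sulfur, this one changes the group on the aromatic nitrogen, and in this assay cyclopropyl in place of ethyl gives no change at the digits printed from compound 2 to compound 4 (within the scatter). With the 3-chlorophenyl group on the sulfonyl sulfur, this nitrogen therefore takes a three-membered ring in place of the ethyl without a step beyond the scatter. Nothing available explains why the two groups read alike. Still open, going by these compounds, is whether a longer chain such as propyl or a bulkier tert-butyl group on this nitrogen would stay level, and whether cyclopropyl would read the same alongside the sulfonyl groups of compound 1 and compound 3.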